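A smaller silicon-bearing group on the same oxygen

The compounds below may be only part of what the source reports. "The series", "measured", "known", "first", "only" and "open" are said of these compounds alone.

Among the compounds with values here, compound 1 `C=C1CC[C@@H]2[C@](C)(CO[Si](C(C)C)(C(C)C)C(C)C)[C@H](O)CC[C@@]2(C)[C@@H]1C/C=C1/C(=O)OC[C@H]1O` gives 2.88 uM in a functional assay on MCF7 cells (Homo sapiens) for cytotoxicity, read by sulforhodamine B assay (on this read-out higher numbers stand for an effect only at larger amounts of compound and lower numbers for an effect already at smaller amounts), the lowest of the three numbers measured so far. Compound 3 `C=C1CC[C@@H]2[C@](C)(CO[Si](c3ccccc3)(c3ccccc3)C(C)(C)C)[C@H](OC(C)=O)CC[C@@]2(C)[C@@H]1C/C=C1/C(=O)OC[C@H]1O` gives 7.53 uM in this assay, a higher number beyond the usual scatter, and compound 2 `C=C1CC[C@@H]2[C@](C)(COC(C)=O)[C@H](O)CC[C@@]2(C)[C@@H]1C/C=C1/C(=O)OC[C@H]1OC(C)=O` gives 18.5 uM, the highest of the three. Compound 4 `C=C1CC[C@@H]2[C@](C)(CO[Si](C)(C)C(C)(C)C)[C@H](O)CC[C@@]2(C)[C@@H]1C/C=C1/C(=O)OC[C@H]1O` differs from compound 1 in one place: a group of 7 heavy atoms (6 carbon, 1 silicon; no ring) in place of a group of 10 heavy atoms (9 carbon, 1 silicon; no ring), on an oxygen on a saturated carbon. Within the data shown here, no measured pair shows this change alone, so its size is uncertain; since both groups are silicon-bearing and carry no donors or acceptors, the expected step of a 1.4-fold higher number from compound 1 to compound 4 (0.14 log units; within the scatter) is small and possibly within the scatter, if anything toward a higher number. Compound 4 is therefore estimated at 4 uM, in a range from 1.5 uM to 11 uM.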

Compound 4, concentration for half-maximal effect: 47 uM
Compound 4: the middle estimate sits 12-fold (1.07 log units) below what was measured; the whole stated range lies below it.
By their numbers in this assay, from the lowest: compound 1; then compound 3; then compound 2; then compound 4.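

On an oxygen on a saturated carbon, the group of 7 heavy atoms in place of the group of 10 heavy atoms gives, in this assay, a 16-fold higher number from compound 1 to compound 4 (1.21 log units; beyond the scatter). Within the data shown here, two silicon-bearing groups with no donors or acceptors are therefore far from interchangeable here, and the earlier compounds, none differing in only one place, could not show this. Nothing available explains the step. Still open, from the compounds shown here alone, is what a free hydroxyl, a benzyl ether or a triphenylsilyl group on this oxygen would give, and whether the number follows group size beyond these two groups.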